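Removing the Fluorine: From Compound 3 to Compound 4

A few compounds are considered here, and "the series" means these few. Any claim that something is new, unique, unknown or untested is made for them only; others in the source may bear on it.

Compound 1 `Cc1ccc2occ(C3N=C(c4ccccc4)SS3)c(=O)c2c1` — 54%
Compound 2 `O=c1c(C(=S)Nc2ccccc2)coc2cc(Cl)ccc12` — 47%
Compound 3 `O=c1c(C2N=C(c3ccccc3)SS2)coc2ccc(F)cc12` — 27%

In a functional assay on OVCAR-3 cells (Homo sapiens) for inhibition, read by sulforhodamine B assay, with a stated time of 48 h, tested at 100 uM (a higher number here means more inhibition of growth at the concentration tested, a lower number less inhibition of growth), compound 3 gives 27%, the lowest of the three numbers. Compound 2 stands nearest to it, and compound 1 furthest, both beyond the scatter. Compound 4 `O=c1c(C2N=C(c3ccccc3)SS2)coc2ccccc12` differs from compound 3 in one place: hydrogen in place of fluoro on an aromatic carbon.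

Among the compounds with values here, only one measured step bears on this change, and only indirectly. Going from the methyl of compound 1 to the fluoro of compound 3 the number moved a number 27 percentage points lower from compound 1 to compound 3 (beyond the scatter). Within the data shown here, no step removes a substituent from this position altogether, so the hydrogen of compound 4 has no measured counterpart; it can only be placed somewhere between the two substituted cases or close to compound 3. Compound 4 is therefore expected to rise modestly, a number 11 percentage points higher from compound 3 to compound 4 (beyond the scatter), with a wide range. The estimate for compound 4 in this assay is 38%, expected to fall between 20% and 58%.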

Compound 4, percent growth inhibition at one concentration: 11%
Compound 4: middle estimate off by 27 percentage points, on the high side, outside the stated range (below it).
By their numbers in this assay, from the lowest: compound 4; then compound 3; then compounds 2 and 1 (each within the scatter of the next).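

In this assay the hydrogen does not fall between the two substituted cases: removing the fluoro gives a number 16 percentage points lower from compound 3 to compound 4 (beyond the scatter) on the same aromatic carbon, so the earlier drop from methyl to fluoro did not mark the low end for this position. The wider comparison, a number 43 percentage points lower from compound 1 to compound 4 (beyond the scatter) at this same carbon, is the largest step seen here and leaves the unsubstituted compound 4 under both substituted compounds, so either substituent goes with more growth inhibition than hydrogen among these three compounds. No measurement available here explains this order.

What the compounds leave open is whether the rise over hydrogen extends to other groups on this carbon, such as chloro, methoxy or an amine. They also leave open whether the same order would hold on the core of compound 2.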